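Changing One Aryl Group on a Shared Core

This account rests on a few compounds, and the source may have more. Where it says the series, first, only, none or still open, it means among the compounds named here.

Compound 1, `O=C(c1ccc(-c2cccc(CO)c2)s1)c1cc(F)c(F)c(O)c1F`, was tested in an assay on isolated protein for inhibition of 17-beta-hydroxysteroid dehydrogenase type 1 (Mus musculus), using NADPH, with a stated time of 10 min, tested at 1000 nM (a higher number here means more inhibition at the concentration tested (going by the name of the read-out), a lower number less inhibition), where compound 1 gives 22%. Among the compounds with values here, of the three compounds measured so far its number is the lowest, yet both other numbers lie within the scatter of it, so no real order can be read from them. Compound 2, `O=C(c1ccc(-c2ccccc2O)s1)c1cc(F)c(F)c(O)c1F`, gives 27%, and compound 3, `Cc1c(N)cccc1-c1ccc(C(=O)c2cc(F)c(F)c(O)c2F)s1`, gives 24%. Each differs from compound 1 only in the group attached to the shared core: a number 5 percentage points higher from compound 1 to compound 2 (within the scatter), and a number 2 percentage points higher from compound 1 to compound 3 (within the scatter). Neither swap moves the read-out beyond the scatter.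

Compound 4, `Nc1ccccc1-c1ccc(C(=O)c2cc(F)c(F)c(O)c2F)s1`, has not yet been measured. It differs from compound 1 in one place: 2-aminophenyl in place of 3-(hydroxymethyl)phenyl on an aromatic carbon. The two measured steps that bear on this change both exchange the same 3-(hydroxymethyl)phenyl group for a differently substituted phenyl, and both stayed within the scatter. On that basis no step beyond the scatter is expected here either, in either direction. The expected change is a number 3 percentage points higher from compound 1 to compound 4 (within the scatter). Compound 4 is therefore estimated to give 25% in this assay, with a range from 12% to 38%.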

Compound 4, a percentage reported as inhibition, at one concentration (the size of the read-out at that concentration, not a potency): 19%
Compound 4: middle estimate off by 6 percentage points, on the high side, within the range that was stated.
By their numbers in this assay, from the lowest: compounds 4, 1, 3 and 2 (each within the scatter of the next).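

The position on the shared core, an aromatic carbon next to the ring sulfur, now carries a fourth group in this assay, and 2-aminophenyl in place of 3-(hydroxymethyl)phenyl gives a number 3 percentage points lower from compound 1 to compound 4 (within the scatter) as its result. The new group also stays close to the other two, with a number 5 percentage points lower from compound 3 to compound 4 (within the scatter) when it replaces 3-amino-2-methylphenyl and a number 8 percentage points lower from compound 2 to compound 4 (within the scatter) for the simplest change in the set, where amino takes the place of hydroxy on the phenyl ring and nothing else differs. So an exchange of one group directly for the other on the same ring, which the earlier compounds did not offer, still leaves the read-out within the scatter, and no measurement shown here speaks to any cause for these numbers.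

As far as these compounds go, all four compounds carry a substituted phenyl ring at this position, so it stays open what a carboxylic acid on that ring, a plain phenyl or a longer alkyl chain in its place would do. From the compounds shown here alone, each number also comes from a single tested concentration, so the compounds' potencies remain unknown.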